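A few compounds are considered here, and "the series" means these few. Any claim that something is new, unique, unknown or untested is made for them only; others in the source may bear on it.

Compound 1 `COc1ccc(-c2cn3ccnc3c(-c3ccc4ncn(C5CCCCC5)c4c3)n2)cc1` gives the lowest number of the three measured compounds in a functional assay on NCI-H522 cells (Homo sapiens) for inhibition, read by sulforhodamine B assay, with a stated time of 48 h, tested at 10 uM (on this read-out lower numbers stand for less inhibition and higher numbers for more inhibition at the one concentration tested (going by the name of the read-out)), where compound 1 gives -20.9%. Both of its measured relatives score higher, each by more than the scatter of repeated runs: compound 2 `O=Cc1ccc(-c2cn3ccnc3c(-c3ccc4ncn(C5CCCCC5)c4c3)n2)cc1` gives 25.3%, and compound 3 `c1cn2cc(-c3ccsc3)nc(-c3ccc4ncn(C5CCCCC5)c4c3)c2n1` gives 10.3%. The two higher compounds also differ from one another, since the result is a number 15 percentage points lower from compound 2 to compound 3 (beyond the scatter).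

The unmeasured compound 4 `c1csc(-c2cn3ccnc3c(-c3ccc4ncn(C5CCCCC5)c4c3)n2)c1` keeps the shared core of compound 1 and alters a single group: thiophen-2-yl in place of 4-methoxyphenyl on an aromatic carbon. Going by the values given here, the closest precedent is the step of a number 31.2 percentage points higher from compound 1 to compound 3 (beyond the scatter), in which a five-membered ring with one sulfur likewise replaced the 4-methoxyphenyl, although attached through a different ring carbon. The step of a number 46.2 percentage points higher from compound 1 to compound 2 (beyond the scatter) adds that the only other alteration made at this outer ring also raised the number, and by a large amount. Among the compounds with values here, no compound so far has moved downward from compound 1.

On that basis compound 4 is expected to rise by roughly a number 30.9 percentage points higher from compound 1 to compound 4 (beyond the scatter). The estimated result for compound 4 is 10%, with a likely range from -15% to 32%.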

Compound 4, a percentage reported as inhibition, at one concentration (the size of the read-out at that concentration, not a potency): 13.2%
For compound 4 the middle estimate is 3.2 percentage points below the measured one; the range from low to high includes it.
By their numbers in this assay, from the lowest: compound 1; then compounds 3 and 4 (each within the scatter of the next); then compound 2.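

In this assay the step of a number 34.1 percentage points higher from compound 1 to compound 4 (beyond the scatter) gives a second case of a five-membered sulfur ring replacing the 4-methoxyphenyl with a large rise, so the earlier gain with compound 3 no longer rests on a single thiophene compound. The new information concerns the point of attachment: the step of a number 2.9 percentage points higher from compound 3 to compound 4 (within the scatter) shows that thiophen-2-yl and thiophen-3-yl cannot be told apart on this read-out, so moving the link from one ring carbon to the other has no visible effect at this position. The thiophene compounds do not match the aldehyde-bearing compound, however, as the step of a number 12.1 percentage points lower from compound 2 to compound 4 (beyond the scatter) keeps 4-formylphenyl as the group with the highest number among the four compounds.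

Nothing available here explains why any of these replacements raises the number. A plain phenyl would show whether removing the methoxy group alone accounts for the rise from compound 1, while an amine or a carboxylic acid on the outer ring would show how far the number follows the kind of group placed there.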